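The compounds below may be only part of what the source reports. "The series", "measured", "known", "first", "only" and "open" are said of these compounds alone.

The three compounds share one core, and in an ADME assay on cell membranes (microsomes) for inhibition of cytochrome P450 1A1 (Homo sapiens), read by fluorescence, tested at 10 uM (on this read-out lower numbers stand for less inhibition and higher numbers for more inhibition at the one concentration tested (going by the name of the read-out)), they spread out. Compound 1 `COc1cc(-c2nc3ccccc3c(=O)[nH]2)ccc1OCc1ccc(Cl)cc1Cl` gives 21.1%. Compound 2 `C#CCOc1cc(-c2nc3ccccc3c(=O)[nH]2)ccc1OC` gives 54.4%, and compound 3 `O=c1[nH]c(-c2ccc(OS(=O)(=O)c3ccccc3)cc2)nc2ccccc12` gives 0.6%. Compound 1 thus stands second highest of the three, closest to compound 3 and furthest from compound 2, with both gaps beyond the scatter.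

Compound 4 `COc1cc(-c2nc3ccccc3c(=O)[nH]2)ccc1OCc1ccc(F)cc1` differs from compound 1 in one place: 4-fluorophenyl in place of 2,4-dichlorophenyl on a saturated chain carbon bound to an oxygen on an aromatic ring. Within the data shown here, the 2,4-dichlorobenzyl becomes a 4-fluorobenzyl, and no measured pair shows this change directly. From compound 1 to compound 4, the step expected is a number 8.9 percentage points higher from compound 1 to compound 4 (within the scatter), a modest rise in inhibition that may well lie within the scatter. Compound 4 is estimated at 30%, with a range from 10% to 55%.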

Compound 4, a percentage reported as inhibition, at one concentration (the size of the read-out at that concentration, not a potency): 6.3%
The estimate for compound 4 lay 23.7 percentage points above the measured number; the whole stated range lies above it.
By their numbers in this assay, from the lowest: compounds 3 and 4 (each within the scatter of the next); then compound 1; then compound 2.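

Putting 4-fluorophenyl in place of 2,4-dichlorophenyl gives a number 14.8 percentage points lower from compound 1 to compound 4 (beyond the scatter) in this assay, so this position does respond to a change in the aromatic ring it carries. The earlier compounds shown here differed in more than one place and could not show this. No measurement at hand explains the fall.

The compounds shown leave open whether the loss of the chlorines or the arrival of the fluorine accounts for the step. They also leave open how an unsubstituted phenyl, a 4-chlorophenyl or a longer chain would read at this place.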